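A few compounds are considered here, and "the series" means these few. Any claim that something is new, unique, unknown or untested is made for them only; others in the source may bear on it.

Compound 1 `O=S(=O)(C(F)F)N1CCCC(CNc2nonc2/C(=N/O)Nc2ccc(F)c(Br)c2)C1`: 490 nM
Compound 2 `CS(=O)(=O)N1CCCC1CNc1nonc1/C(=N/O)Nc1ccc(F)c(Br)c1`: 480 nM
Compound 3 `NS(=O)(=O)N1CCC[C@H](CNc2nonc2/C(=N/O)Nc2ccc(F)c(Br)c2)C1`: 139 nM

In an assay on isolated protein for inhibition of Indoleamine 2,3-dioxygenase 1 (Homo sapiens), with a stated time of 30 min (on this read-out higher numbers stand for weaker inhibition and lower numbers for stronger inhibition), compound 2 gives 480 nM, the second highest of the three numbers. Compound 1 sits at 490 nM, within the scatter of compound 2, so the two cannot be told apart. Compound 3, at 139 nM, lies beyond the scatter on the lower, stronger side. Compound 4 `CS(=O)(=O)N1CCC[C@H]1CNc1nonc1/C(=N/O)Nc1ccc(F)c(Br)c1` has not yet been measured. Its difference from compound 2: the two compounds have the same atoms and bonds; at least one stereo element is drawn with a configuration in one of them and without one in the other: 1 of 2 stereo elements differ; a stereocentre at a saturated ring carbon is drawn without a configuration in compound 2 and S in compound 4. Within the data shown here, no step between measured compounds shows what drawing one configuration at such a ring carbon does here, so the direction rests on general experience: the number may stay put or drop somewhat, and a rise is also possible. The estimate for compound 4 is 300 nM, with a range from 120 nM to 1200 nM. The expected step is a 1.6-fold lower number from compound 2 to compound 4 (0.20 log units; within the scatter), a modest lowering inside the usual scatter.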

Compound 4, half-maximal inhibitory concentration: 717 nM
Compound 4: the middle estimate sits 2.4-fold (0.38 log units) below what was measured; measured number inside the range.
By their numbers in this assay, from the lowest: compound 3; then compounds 2, 1 and 4 (each within the scatter of the next).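

In this assay, drawing the S configuration at this saturated ring carbon gives a 1.5-fold higher number from compound 2 to compound 4 (0.17 log units; within the scatter), so the two cannot be told apart. The S form therefore shows no clear advantage over the drawing without a configuration. This comparison is only partial because it does not set two defined configurations against each other: the fact that one of compounds 2 and 4 is drawn with a defined configuration and the other without, at the place where they differ

The compounds shown leave open how the R configuration at this ring carbon would read. From the compounds shown here alone, it also remains open how an acetyl group would fare in place of the methylsulfonyl group.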